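From 3-sulfamoylphenyl to 2-methoxyphenyl on the amide

The source may report more compounds than this note shows. Statements on the series, on what has been measured and on what is new or still open speak of the compounds shown alone.

Measured in an ADME assay on MT4 cells (Homo sapiens) for cytotoxicity, read by MTT assay, with a stated time of 5 days; on this read-out lower numbers stand for higher toxicity in this test and higher numbers for lower toxicity in this test:
- compound 1 `COc1cc2nc([S+]([O-])CC(=O)Nc3ccccc3F)nc(Nc3c(Cl)cc(/C=C/C#N)cc3Cl)c2cc1OC`: > 208000 nM
- compound 2 `COc1cc2nc([S+]([O-])CC(=O)Nc3cccc(S(N)(=O)=O)c3)nc(Nc3c(Cl)cc(/C=C/C#N)cc3Cl)c2cc1OC`: 67800 nM

Compound 1 stands at > 208000 nM, which is a limit of the assay and not a number.

For the measured compounds named here, compound 2, at 67800 nM, holds the only true number so far, so it cannot yet be placed in a series of numbers. Going by the values given here, compound 3 `COc1ccccc1NC(=O)C[S+]([O-])c1nc(Nc2c(Cl)cc(/C=C/C#N)cc2Cl)c2cc(OC)c(OC)cc2n1` keeps the shared core and changes only one group: 2-methoxyphenyl in place of 3-sulfamoylphenyl on an amide-type nitrogen. In short, 2-methoxyphenyl takes the place of 3-sulfamoylphenyl on an amide-type nitrogen.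

Among the compounds with values here, one measured step bears on this, since it changed the same place: an at least 3.0-fold lower number from compound 1 to compound 2 (0.48 log units; beyond the scatter). That step lies beyond the scatter and came with the arrival of 3-sulfamoylphenyl. Compound 3 gives that group up again, so a move back towards higher numbers in this assay seems likely, although a single step is thin evidence and the new group differs from the 2-fluorophenyl of compound 1. The expected change is a 2.5-fold higher number from compound 2 to compound 3 (0.40 log units; beyond the scatter). The estimate for compound 3 is 170000 nM, with an expected range from 70000 nM to 260000 nM.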

Compound 3, half-maximal cytotoxic concentration: > 204000 nM
Compound 3 ended at the assay's limit; the forecaster's own chance of this, stated with the estimate: 55%; middle value at least 1.2-fold (0.07 log units) from the limit.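

In this assay, the step at this amide-type nitrogen has now been seen in both directions: 2-fluorophenyl gave way to 3-sulfamoylphenyl with a drop, and replacing that group with 2-methoxyphenyl gives an at least 3.0-fold higher number from compound 2 to compound 3 (0.47 log units; beyond the scatter) beyond the scatter. Among these three compounds, the lower number therefore goes with 3-sulfamoylphenyl, meaning higher toxicity in this test, and not with every substituted phenyl on this nitrogen, and no compound shown goes against this. The 2-fluorophenyl of compound 1 and the 2-methoxyphenyl of compound 3 both end at limits of the assay and not at numbers, so the step between them cannot be read, and these two groups cannot be ranked against each other.

As far as these compounds go, how much toxicity compound 1 and compound 3 would show at still higher concentrations remains unknown, as does whether they differ at all. Also open, from the compounds shown here alone, is whether the lower number is specific to the sulfamoyl group, or whether a phenyl ring carrying a carboxylic acid or an amine on this same nitrogen would give a similar result.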